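The compounds below may be only part of what the source reports. "The series", "measured", "known", "first", "only" and "open" are said of these compounds alone.

Measured compounds in a functional assay on CHO cells with adenosine receptor A1 (Homo sapiens) as the target, read by cAMP accumulation and immunoassay, with a stated time of 6 min, tested at 0.01 uM; a higher number here means a weaker effect of the compound at the concentration tested, a lower number a stronger effect:
compound 1 `Nc1scc(CN2CCN(c3cccc(Cl)c3Cl)CC2)c1C(=O)c1ccc(Cl)cc1`: 1%
compound 2 `Nc1scc(CN2CCN(c3ccc([N+](=O)[O-])cc3)CC2)c1C(=O)c1ccc(Cl)cc1`: -12%
compound 3 `Nc1scc(CN2CCN(c3ccccc3F)CC2)c1C(=O)c1ccc(Cl)cc1`: 2.1%

Compound 1 stands second highest of the three numbers. Its nearest neighbour is compound 3, which lies within the scatter of it (a number 1.1 percentage points higher from compound 1 to compound 3 (within the scatter)); its furthest is compound 2 (a number 13 percentage points lower from compound 1 to compound 2 (beyond the scatter)), a modest step beyond the scatter. Compound 4 `Nc1scc(CN2CCN(c3ccc(F)cc3F)CC2)c1C(=O)c1ccc(Cl)cc1` is not yet measured in this assay. It differs from compound 1 in one place: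

2,4-difluorophenyl in place of 2,3-dichlorophenyl on an amine nitrogen in a ring

For the measured compounds named here, the step that bears most directly on this change is the one from compound 1 to compound 3, a halogen-for-halogen swap on the same ring that stayed within the scatter; the move to a nitro group in compound 2 was the only one beyond it. Because of a number 1.1 percentage points higher from compound 1 to compound 3 (within the scatter), compound 4 is expected to show no step beyond the scatter, no change at the digits printed from compound 1 to compound 4 (within the scatter). The estimate for compound 4 is 1%, within -10% to 12%.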

Compound 4, a percentage reported as activity, at one concentration (the size of the read-out at that concentration, not a potency): 0%
For compound 4 the middle estimate is 1 percentage points above the measured one; the range from low to high includes it.
By their numbers in this assay, from the lowest: compound 2; then compounds 4, 1 and 3 (each within the scatter of the next).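

In this assay, fluoro in place of hydrogen on an aromatic carbon gives a number 2.1 percentage points lower from compound 3 to compound 4 (within the scatter), and the full swap of halogen pattern gives a number 1 percentage points lower from compound 1 to compound 4 (within the scatter), so fluoro and chloro patterns on this phenyl ring read alike here. The 4-nitrophenyl group stays apart from the new compound, with a number 12 percentage points higher from compound 2 to compound 4 (beyond the scatter). No measurement here offers an explanation for these readings. Going by these compounds, whether that step is specific to the nitro group remains open, and a methoxy or a nitrile on the same ring would bear on it.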